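TLR8 agonists: swapping the amide substituent on the shared core

The compounds below may be only part of what the source reports. "The series", "measured", "known", "first", "only" and "open" are said of these compounds alone.

Measured so far:
compound 1 `CCCCNc1nc(N)nc2c1CN(S(C)(=O)=O)CC2` — 9.9 uM
compound 2 `CCCCNc1nc(N)nc2c1CN(C(=O)C(C)C)CC2` — 1.6 uM

In an assay on HEK293 cells for agonist activity at Toll-like receptor 8 (Homo sapiens), read by a luciferase reporter, with a stated time of 6 h (a higher number here means that more compound is needed for the effect, a lower number that less compound is needed), compound 2 gives the lower of the two numbers, with a 6.2-fold lower number from compound 1 to compound 2 (0.79 log units; beyond the scatter). Compound 3 `CCCCNc1nc(N)nc2c1CN(C(=O)c1cc(C)on1)CC2` keeps that core and changes only the amide substituent: 5-methyl-1,2-oxazol-3-yl in place of isopropyl on a carbonyl carbon. Among the measured compounds shown here, the single measured step, from compound 1 to compound 2, also concerns this amide position and was modest, so it hints that the group here matters without showing which direction an aromatic ring takes. Compound 3 is therefore expected to land near compound 2, as a 1.6-fold lower number from compound 2 to compound 3 (0.20 log units; within the scatter), with an estimated value of 1 uM (range 0.3 uM to 4 uM).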

Compound 3, minimum effective concentration: 0.4 uM
Estimate against measurement, compound 3: 2.5-fold (0.40 log units) above, and the stated range covers the measured number.
By their numbers in this assay, from the lowest: compound 3; then compound 2; then compound 1.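

In this assay, this position proves to respond to more than the swap of the earlier pair: 5-methyl-1,2-oxazol-3-yl in place of isopropyl on the carbonyl carbon gives a 4.0-fold lower number from compound 2 to compound 3 (0.60 log units; beyond the scatter) and so lowers the number further. Measured against the methylsulfonyl group, (5-methyl-1,2-oxazol-3-yl)carbonyl gives a 25-fold lower number from compound 1 to compound 3 (1.39 log units; beyond the scatter) and this is a large step for one change on the ring nitrogen. Nothing available here explains the gain.

From the compounds shown here alone, whether it comes from the ring or from its methyl group stays open. How a phenyl ring or a longer chain on the carbonyl carbon would compare is also unknown.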